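Swapping the Aryl Group on a Shared Core

The source may hold more compounds than are shown below. What is called first, only, known or untested is meant among the compounds shown, and "the series" means these compounds.

Of the compounds shown here, three built on one shared core have been tested in a functional assay, with a stated time of 20 min; on this read-out lower numbers stand for stronger inhibition and higher numbers for weaker inhibition. Compound 1 `CSc1nc(-c2ccco2)c(C#N)c(=O)n1C` gives 68 ug/mL. Compound 2 `COc1cccc(-c2nc(SC)n(C)c(=O)c2C#N)c1OC` gives 54 ug/mL. Compound 3 `CCOC(=O)c1cnn(-c2nc(-c3ccccc3O)c(C#N)c(=O)n2C)c1N` gives 48 ug/mL, the lowest of the three numbers, yet its gaps to compound 2 and to compound 1 both fall within the usual scatter, so no order among the three can be claimed. Compound 4 `CCOC(=O)c1cnn(-c2nc(-c3cccc(OC)c3OC)c(C#N)c(=O)n2C)c1N` has not yet been measured. It differs from compound 3 in one place: 2,3-dimethoxyphenyl in place of 2-hydroxyphenyl on an aromatic carbon. Compound 2 carries the same 2,3-dimethoxyphenyl group on a different core and gives 54 ug/mL, close to compound 3, so the expected step is a 1.0-fold higher number from compound 3 to compound 4 (0.02 log units; within the scatter), nothing beyond the scatter. Compound 4 is estimated at 50 ug/mL, with a likely range from 25 ug/mL to 100 ug/mL.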

Compound 4, half-maximal inhibitory concentration: 54 ug/mL
For compound 4 the middle estimate is 1.1-fold (0.03 log units) below the measured one; the measured number falls inside the stated range.
By their numbers in this assay, from the lowest: compounds 3, 2, 4 and 1 (each within the scatter of the next).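

In this assay, putting 2,3-dimethoxyphenyl in place of 2-hydroxyphenyl on this aromatic carbon gives a 1.1-fold higher number from compound 3 to compound 4 (0.05 log units; within the scatter). At this position, then, the read-out does not separate the two groups, although the entering group is larger and has no hydrogen-bond donor while the leaving group has one. Nothing measured here bears on why. Going by these compounds, both groups are substituted phenyl rings, so it remains open whether a different kind of group here, such as an amine or a carboxylic acid, would give a number beyond the scatter.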